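Replacing the sulfonylamino group with hydroxymethyl

A few compounds are considered here, and "the series" means these few. Any claim that something is new, unique, unknown or untested is made for them only; others in the source may bear on it.

In a functional assay on HepG2 cells (Homo sapiens) for antiproliferative activity, read by MTT assay, with a stated time of 72 h (on this read-out higher numbers stand for weaker inhibition and lower numbers for stronger inhibition), compound 1 (`O=C1O[C@H]([C@@H](O)Cn2cc(CNS(=O)(=O)c3ccc(Cl)cc3)nn2)C(OCc2ccccc2)=C1OCc1ccccc1`) gives 7510 nM and compound 2 (`Cc1ccc(S(=O)(=O)NCc2cn(C[C@H](O)[C@H]3OC(=O)C(OCc4ccccc4)=C3OCc3ccccc3)nn2)cc1`) gives 24900 nM, so compound 2 stands at the higher, weaker end of the two numbers. Going by the values given here, the one measured step, a 3.3-fold higher number from compound 1 to compound 2 (0.52 log units; beyond the scatter), is modest but beyond the scatter, and it comes from methyl in place of chloro on an aromatic carbon.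

Compound 3 (`O=C1O[C@H]([C@@H](O)Cn2cc(CCO)nn2)C(OCc2ccccc2)=C1OCc1ccccc1`) keeps the shared core and changes the side chain: hydroxymethyl in place of ((4-methylphenyl)sulfonyl)amino on a saturated chain carbon bound to an aromatic carbon. In words, hydroxymethyl replaces ((4-methylphenyl)sulfonyl)amino on a saturated chain carbon bound to an aromatic carbon.

The measured step bears on this only indirectly: the aromatic ring it edited leaves entirely here. It shows that this assay responds to a change on that ring, but it gives no size or direction for removing the ring. The working expectation is therefore no shift beyond the scatter, with a slight lean towards weaker inhibition and wide uncertainty. The expected change is a 1.2-fold higher number from compound 2 to compound 3 (0.08 log units; within the scatter). Compound 3 is estimated at 30000 nM, with an expected range of 8000 nM to 100000 nM.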

Compound 3, half-maximal inhibitory concentration: 68100 nM
The estimate for compound 3 lay 2.3-fold (0.36 log units) below the measured number; the measured number falls inside the stated range.
By their numbers in this assay, from the lowest: compound 1; then compound 2; then compound 3.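

In this assay, replacing ((4-methylphenyl)sulfonyl)amino with hydroxymethyl on a saturated chain carbon bound to an aromatic carbon gives a 2.7-fold higher number from compound 2 to compound 3 (0.44 log units; beyond the scatter), so the full loss of this group and its aromatic ring weakens inhibition rather than leaving it unchanged. Replacing ((4-chlorophenyl)sulfonyl)amino with hydroxymethyl at the same place gives a 9.1-fold higher number from compound 1 to compound 3 (0.96 log units; beyond the scatter), the largest step in the series, which places compound 3 at the weak end with both sulfonylamino compounds clearly stronger. No measurement on hand gives a reason for these steps.

The change removes the sulfonyl group, the amino nitrogen and the aromatic ring together, so the compounds shown do not tell which of these parts carries the difference between the sulfonylamino compounds and compound 3. Also open, going by these compounds, is how a primary amine or a carboxylic acid would compare with hydroxymethyl at this place, and whether a plain phenylsulfonylamino group or a methoxy group on the ring would fall within the range set by the chloro and methyl compounds.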